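The source may report more compounds than this note shows. Statements on the series, on what has been measured and on what is new or still open speak of the compounds shown alone.

Of the compounds shown here, three have been measured in a functional assay on membranes from Sf9 cells for agonist activity at histamine H2 receptor (Homo sapiens), read by scintillation counting and GTPgammaS binding, with a stated time of 90 min; a lower number here means that less compound is needed, a higher number that more compound is needed for the effect. Compound 1 `Cc1nc(N)sc1CCCN/C(N)=N/C(=O)NC1CCCCC1` gives 148 nM in this assay. Compound 3 `CCCCCCNC(=O)/N=C(\N)NC1CCc2nc(N)sc2C1` gives 148 nM, which at the digits shown is level with compound 1; together these two hold the highest number of the three. Compound 2 `Cc1nc(N)sc1CCCN/C(N)=N/C(=O)NCC(C)CCc1ccccc1` gives 29.5 nM, a markedly lower number than that of compound 1, well beyond the usual scatter. Compound 4 `Cc1nc(N)sc1CCCN/C(N)=N/C(=O)Nc1ccccc1` has not yet been measured. It differs from compound 1 in one place: phenyl in place of cyclohexyl on an amide-type nitrogen. Among the measured compounds shown here, no measured pair shows this same exchange, so its effect cannot be read from the data at hand. The step of a 1.4-fold higher number from compound 1 to compound 4 (0.13 log units; within the scatter) is expected to be small, staying within the scatter. Compound 4 is estimated at 200 nM, with a likely range from 60 nM to 650 nM.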

Compound 4, half-maximal effective concentration: 525 nM
Beside the measured number, compound 4's estimate is 2.6-fold (0.42 log units) below it; the range from low to high includes it.
By their numbers in this assay, from the lowest: compound 2; then compounds 1 and 3 (each within the scatter of the next); then compound 4.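

In this assay, the ring on the amide-type nitrogen cannot be swapped freely: phenyl in place of cyclohexyl gives a 3.5-fold higher number from compound 1 to compound 4 (0.55 log units; beyond the scatter) even though both are six-membered carbon rings of equal heavy-atom count. The earlier compounds shown here did not show that an aromatic and a non-aromatic ring can differ at this position. Nothing measured here explains the step.

This single pair leaves open whether the exchange behaves the same on another core. Going by these compounds, how a benzyl group or a cyclopentyl ring would compare at this position also remains open.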